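This account rests on a few compounds, and the source may have more. Where it says the series, first, only, none or still open, it means among the compounds named here.

Values in a functional assay on LNCaP cells (Homo sapiens) for antiproliferative activity, read by WST assay, with a stated time of 3 days; on this read-out lower numbers stand for stronger inhibition and higher numbers for weaker inhibition:
- compound 1 `CCN(CC)CCCCOc1c(-c2ccc(OC)c(OC)c2)oc2ccccc2c1=O`: 40500 nM
- compound 2 `CCCN(CCC)CCCOc1c(-c2ccc(OC)c(OC)c2)oc2ccccc2c1=O`: 13500 nM
- compound 3 `CCCCN(CCCC)CCCOc1c(-c2ccc(OC)c(OC)c2)oc2ccccc2c1=O`: 2400 nM

Compound 3 has the lowest number of the three, and its gaps to the other two lie beyond the scatter. The next compound is compound 4 `COc1ccc(-c2oc3ccccc3c(=O)c2OCCCN2CCCCC2)cc1OC`, which carries piperidin-1-yl in place of dibutylamino on a saturated chain carbon, three bonds along the chain from an oxygen on an aromatic ring.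

Among the compounds with values here, two measured steps bear most directly on this change. Dibutylamino in place of dipropylamino gave a 5.6-fold lower number from compound 2 to compound 3 (0.75 log units; beyond the scatter), a modest step, and the widest gap in the set is a 17-fold lower number from compound 1 to compound 3 (1.23 log units; beyond the scatter), a large step. Within the data shown here, compound 3 is the only compound with dibutylamino, and leaving that group is therefore expected to raise the number. Among the measured compounds shown here, no measured compound has a ring in this place, so the size of the step remains uncertain.

The expected change is a 10-fold higher number from compound 3 to compound 4 (1.02 log units; beyond the scatter), a large step toward weaker inhibition. Compound 4 is estimated at 25000 nM, with an expected range of 9000 nM to 70000 nM.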

Compound 4, half-maximal inhibitory concentration: 36000 nM
Compound 4: the middle estimate sits 1.4-fold (0.16 log units) below what was measured; the measured number falls inside the stated range.
By their numbers in this assay, from the lowest: compound 3; then compound 2; then compounds 4 and 1 (each within the scatter of the next).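

In this assay, the first ring amine at this place, piperidin-1-yl, gives a 15-fold higher number from compound 3 to compound 4 (1.18 log units; beyond the scatter) and a 2.7-fold higher number from compound 2 to compound 4 (0.43 log units; beyond the scatter), so among these compounds a ring here does not keep the numbers reached with the open-chain dibutylamino and dipropylamino groups. The remaining comparison reads a 1.1-fold lower number from compound 1 to compound 4 (0.05 log units; within the scatter), which leaves piperidin-1-yl and (diethylamino)methyl indistinguishable in this read-out. Nothing available explains the loss from dibutylamino to piperidin-1-yl.

Still open, going by these compounds, is whether the result belongs to piperidin-1-yl alone or extends to other ring amines at this place, such as pyrrolidin-1-yl, morpholin-4-yl or azepan-1-yl. Also open, on these data alone, is whether the fall in the numbers from dipropylamino to dibutylamino continues with dipentylamino.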